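The compounds below may be only part of what the source reports. "The series", "measured", "known", "first", "only" and "open" are said of these compounds alone.

Of the compounds shown here, three of a shared core have been measured in an ADME assay for permeability, using PAMPA, with a stated time of 30 min, at pH 7.4; a higher number here means that the compound crosses the layer faster, a lower number that the compound crosses the layer more slowly. Compound 1 `COc1ccc(F)cc1CNCCCNc1ccnc2cc(Cc3ccc(F)cc3Cl)ccc12` gives 23 10^-6 cm/s. Compound 3 `Fc1ccc(Cc2ccc3c(NCCCNCc4ccco4)ccnc3c2)c(Cl)c1` gives 23 10^-6 cm/s, and compound 2 `COc1cccc(CNCCCNc2ccnc3cc(Oc4cccc(N(C)C)c4)ccc23)c1O` gives 317 10^-6 cm/s. Compound 1 thus stands level with compound 3, the two together being the lowest of the three numbers, while compound 2 lies a long way higher.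

Among the compounds with values here, the one step between measured compounds that differ in a single place runs no change at the digits printed from compound 1 to compound 3 (within the scatter), and that change sits on the saturated chain carbon bound to an amine nitrogen, at the other end of the molecule from the change now considered.

Compound 4 `COc1ccc(F)cc1CNCCCNc1ccnc2cc(Oc3ccc(Cl)cc3)ccc12` differs from compound 1 by 4-chlorophenoxy in place of 2-chloro-4-fluorobenzyl on an aromatic carbon. Within the data shown here, no measured step alters this particular position on its own. Compound 2 carries a phenoxy group at the same kind of place and gives a far higher number than compound 1, but compound 2 also differs from compound 1 elsewhere, so its value can only hint at the direction. A moderate rise is therefore expected, with wide uncertainty, and compound 4 is estimated at 45 10^-6 cm/s, between 15 10^-6 cm/s and 140 10^-6 cm/s, a step of a 2.0-fold higher number from compound 1 to compound 4 (0.29 log units; within the scatter).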

Compound 4, apparent permeability: 317 10^-6 cm/s
Compound 4: the middle estimate sits 7.0-fold (0.85 log units) below what was measured, and the stated range ends below it.
By their numbers in this assay, from the lowest: compounds 1 and 3 (each within the scatter of the next); then compounds 2 and 4 (each within the scatter of the next).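

In this assay, putting 4-chlorophenoxy in place of 2-chloro-4-fluorobenzyl on this aromatic carbon gives a 14-fold higher number from compound 1 to compound 4 (1.14 log units; beyond the scatter) as the outcome of a change in one place, so this position alone can move the number by a large amount. The only earlier one-place change, on a saturated chain carbon bound to an amine nitrogen, gave no change at the digits printed from compound 1 to compound 3 (within the scatter) as its outcome, and so among these compounds a clear shift appears only at the aromatic position. The swap is still a bundle of differences rather than a single atom's change: a fluorine leaves, an oxygen enters as the link to the ring, and the group's chlorine is placed differently, as the two group names show.

No measurement offered here gives a reason for the rise. Nothing shown separates the effect of the oxygen link from that of the altered ring, and the numbers that 4-chlorobenzyl or 4-fluorophenoxy would give on the same aromatic carbon remain open.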